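Aryl exchange from compound 2 to compound 3

This account rests on a few compounds, and the source may have more. Where it says the series, first, only, none or still open, it means among the compounds named here.

In a functional assay on RXF 393 cells (Homo sapiens) for inhibition, read by sulforhodamine B assay, with a stated time of 48 h (on this read-out lower numbers stand for stronger inhibition of growth and higher numbers for weaker inhibition of growth), compound 1 (`O=C(Cc1csc2nc(-c3ccc(Br)cc3)cn12)N/N=C/c1ccccc1O`) gives 38000 nM and compound 2 (`COc1cccc(OC)c1/C=N/NC(=O)Cc1csc2nc(-c3ccc(Br)cc3)cn12`) gives 19100 nM. Going by the values given here, compound 2 therefore stands within the scatter of compound 1, the only other measured compound. Compound 3 (`O=C(Cc1csc2nc(-c3ccc(Br)cc3)cn12)N/N=C/c1ccc(Cl)cc1Cl`) differs from compound 2 as follows: 2,4-dichlorophenyl in place of 2,6-dimethoxyphenyl on a carbon with a double bond to nitrogen. Among the compounds with values here, the one measured step bearing on this place, a 2.0-fold lower number from compound 1 to compound 2 (0.30 log units; within the scatter), is small. Within the data shown here, no measured compound carries a 2,4-dichlorophenyl, so no change beyond the scatter is expected in this assay. The expected step is a 1.1-fold lower number from compound 2 to compound 3 (0.05 log units; within the scatter). For compound 3 the estimate is 17000 nM, with an expected range of 6000 nM to 50000 nM.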

Compound 3, concentration for 50% growth inhibition: 28200 nM
The estimate for compound 3 lay 1.7-fold (0.22 log units) below the measured number, within the range that was stated.
By their numbers in this assay, from the lowest: compounds 2, 3 and 1 (each within the scatter of the next).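

In this assay, 2,4-dichlorophenyl at this place gives a 1.5-fold higher number from compound 2 to compound 3 (0.17 log units; within the scatter) and a 1.3-fold lower number from compound 1 to compound 3 (0.13 log units; within the scatter), so all three aryl groups on a carbon with a double bond to nitrogen lie within the scatter of one another. Exchanging 2,6-dimethoxyphenyl, with 2 hydrogen-bond acceptors, for 2,4-dichlorophenyl, with 0, therefore produces no readable change. No evidence is at hand that bears on this result. On these data alone, whether an amine or a carboxylic acid in place of these aryl groups would move the number beyond the scatter stays open. The shown compounds also leave open whether any change to the shared core would do so.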